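The compounds below may be only part of what the source reports. "The series", "measured", "known", "first", "only" and "open" are said of these compounds alone.

Of the compounds shown here, two sharing one core have so far been measured in a functional assay on BV-2 cells (Mus musculus) for inhibition, read by Griess assay, with stated times of 3 h and 24 h; a higher number here means a weaker inhibitor, a lower number a stronger inhibitor. Compound 1 `[O-][S+](/C=C/c1ccc(O)c(O)c1)Cc1ccccc1` gives 50300 nM in this assay. Compound 2 `[O-][S+](/C=C/c1ccc(O)c(O)c1)Cc1ccc(C(F)(F)F)cc1`, which carries a trifluoromethyl in place of a hydrogen on an aromatic carbon, gives 15500 nM in this assay. The step of a 3.2-fold lower number from compound 1 to compound 2 (0.51 log units; beyond the scatter) leaves compound 2 with the lowest of the two numbers seen, its nearest neighbour being compound 1. Compound 3 `COc1ccc(C[S+]([O-])/C=C/c2ccc(O)c(O)c2)cc1` differs from compound 2 by methoxy in place of trifluoromethyl on an aromatic carbon. Within the data shown here, no measured step involves a methoxy, so the only step that bears on this change is a 3.2-fold lower number from compound 1 to compound 2 (0.51 log units; beyond the scatter), which shows how far the trifluoromethyl moved the number away from the unsubstituted compound 1. Taking the methoxy compound as likely to land between the two measured compounds, the expected step is a 2.3-fold higher number from compound 2 to compound 3 (0.35 log units; beyond the scatter). Compound 3 is therefore estimated at 35000 nM, with a range from 12000 nM to 90000 nM.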

Compound 3, half-maximal inhibitory concentration: 33000 nM
Compound 3: middle estimate off by 1.1-fold (0.03 log units), on the high side, and the stated range covers the measured number.
By their numbers in this assay, from the lowest: compound 2; then compounds 3 and 1 (each within the scatter of the next).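

In this assay a group on this aromatic carbon does not by itself shift the number: methoxy in place of hydrogen gives a 1.5-fold lower number from compound 1 to compound 3 (0.18 log units; within the scatter) and so leaves compound 3 not separable from compound 1. Methoxy in place of trifluoromethyl gives a 2.1-fold higher number from compound 2 to compound 3 (0.33 log units; beyond the scatter) and so, among these three compounds, the lower number of compound 2 goes with trifluoromethyl and not with just any group placed here. No measurement to hand explains why these two groups differ.

Two groups on one aromatic carbon cannot show whether a chlorine, a nitrile or a carboxylic acid there would behave like trifluoromethyl or like methoxy. From the compounds shown here alone, it also stays open whether trifluoromethyl would keep the lower number on another carbon of the same ring.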